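This account rests on a few compounds, and the source may have more. Where it says the series, first, only, none or still open, it means among the compounds named here.

Of the compounds shown here, three built on a shared core have so far been measured in a functional assay on a cell-free system (plasma, Homo sapiens), with a stated time of 3 min; on this read-out lower numbers stand for stronger inhibition and higher numbers for weaker inhibition. Compound 1 `CC(C)(C)[C@@H](O)C(=O)N1[C@@H]2C[C@@H]2C[C@H]1C(=O)NCc1cc(Cl)ccc1-n1cnnn1` gives 1100 nM in this assay. Compound 2 `CCCC[C@@H](O)C(=O)N1N=CC[C@H]1C(=O)NCc1cc(Cl)ccc1-n1cnnn1` gives 610 nM in this assay, the lowest of the three numbers. Compound 3 `CC(C)(C)C[C@@H](O)C(=O)N1OCC[C@H]1C(=O)NCc1cc(Cl)ccc1-n1cnnn1` gives 1100 nM in this assay. The gap from compound 2 to compound 1 and the gap from compound 2 to compound 3 both lie within the usual scatter, so the three numbers stand together and no order among them can be claimed.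

Compound 4 `O=C(NCc1cc(Cl)ccc1-n1cnnn1)[C@@H]1CC=NN1C(=O)[C@H](O)c1ccccc1F` has not yet been measured. It differs from compound 2 in one place: 2-fluorophenyl in place of butyl on a saturated chain carbon bound to a carbonyl carbon and an oxygen on a saturated carbon. Within the data shown here, no pair of measured compounds differs by a matching exchange, so there is no measured step to lean on. The three measured compounds differ from one another at several places, and their numbers all stay within the scatter of one another, which gives no sign that a change at this position moves the read-out strongly. The step from compound 2 to compound 4 is therefore expected to be small, with no direction beyond the scatter: a 1.1-fold lower number from compound 2 to compound 4 (0.04 log units; within the scatter) is the expected change. Compound 4 is estimated to give 550 nM in this assay, expected to fall between 180 nM and 1700 nM.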

Compound 4, half-maximal inhibitory concentration: 1100 nM
For compound 4 the middle estimate is 2.0-fold (0.30 log units) below the measured one, and the stated range covers the measured number.
By their numbers in this assay, from the lowest: compounds 2, 1, 3 and 4 (each within the scatter of the next).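

In this assay, among these compounds, the exchange of butyl for 2-fluorophenyl on a saturated chain carbon bound to a carbonyl carbon and an oxygen on a saturated carbon gives a 1.8-fold higher number from compound 2 to compound 4 (0.26 log units; within the scatter), and this is the first step in the set that changes one place only. The earlier compounds shown here differed from one another at several places, so they could not isolate this position, whereas this pair shows that replacing an open chain with a six-membered aromatic ring of carbon only, which also brings more heavy atoms, produces no change that can be claimed on this read-out. Nothing measured here bears on why the two groups cannot be told apart.

The compounds shown leave open whether the same holds for a group of a different kind at this place, such as an amine or a carboxylic acid, or for a chain longer than butyl. They also leave open what the fluorine contributes, a question that a plain phenyl at this place could address when read against compound 4.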